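This account rests on a few compounds, and the source may have more. Where it says the series, first, only, none or still open, it means among the compounds named here.

In a functional assay on A549 cells (Homo sapiens) for cytotoxicity, read by MTT assay, with a stated time of 72 h (on this read-out lower numbers stand for stronger inhibition and higher numbers for weaker inhibition), compound 2 `CN1CCN(CCCCOc2c(OCc3cccs3)cc(O)c3c(=O)cc(-c4ccccc4)oc23)CC1` gives 2100 nM. Among the compounds with values here, its only measured neighbour, compound 1 `CN1CCN(CCCCOc2c(OCc3ccc(C#N)cc3)cc(O)c3c(=O)cc(-c4ccccc4)oc23)CC1`, gives in this assay 2140 nM; the step of a 1.0-fold lower number from compound 1 to compound 2 (0.01 log units; within the scatter) lies within the scatter, so on these two numbers the compounds cannot be told apart, and compound 2 holds no separate standing of its own. Compound 3 `CN1CCN(CCCCOc2c(OCc3nc4ccccc4o3)cc(O)c3c(=O)cc(-c4ccccc4)oc23)CC1` has not yet been measured. It differs from compound 2 in one place: 1,3-benzoxazol-2-yl in place of thiophen-2-yl on a saturated chain carbon bound to an oxygen on an aromatic ring. Within the data shown here, the single measured step that bears on this change is a 1.0-fold lower number from compound 1 to compound 2 (0.01 log units; within the scatter), in which one aromatic group on the same saturated chain carbon was exchanged for another without any shift beyond the scatter. Among the measured compounds shown here, only that one exchange is known, and the group that enters here is a different kind of group from either of the two already compared, so the expectation rests on thin ground. On that evidence the account expects the step of a 1.0-fold higher number from compound 2 to compound 3 (0.02 log units; within the scatter) to stay within the scatter, in no settled direction. Compound 3 is therefore estimated at 2200 nM, with a range from 900 nM to 5500 nM.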

Compound 3, half-maximal inhibitory concentration: 3870 nM
Compound 3: middle estimate off by 1.8-fold (0.25 log units), on the low side; measured number inside the range.
By their numbers in this assay, from the lowest: compounds 2, 1 and 3 (each within the scatter of the next).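

In this assay, the steps of a 1.8-fold higher number from compound 2 to compound 3 (0.27 log units; within the scatter) and a 1.8-fold higher number from compound 1 to compound 3 (0.26 log units; within the scatter) both stay inside the usual spread of repeated measurements, so three aromatic groups at this place, on a saturated chain carbon bound to an oxygen on an aromatic ring, cannot be told apart. The earlier pair compared only groups with a single ring, whereas 1,3-benzoxazol-2-yl brings a five-membered aromatic ring with 2 hetero atoms together with a six-membered aromatic ring of carbon only, and even this exchange gives no step beyond the scatter. No measurement at hand speaks to the reason for this result.

As far as these compounds go, what stays open is whether this place tolerates only aromatic groups, since an amine, a carboxylic acid or a plain alkyl chain on the same saturated chain carbon would test something that none of the three compounds tests. From the compounds shown here alone, all three also share the rest of their structure, so it remains open whether the same picture would hold with a longer chain elsewhere in the molecule, or in any read-out other than this assay.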